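Methyl in Place of Methoxy on the Aromatic Ring

A few compounds are considered here, and "the series" means these few. Any claim that something is new, unique, unknown or untested is made for them only; others in the source may bear on it.

Compound 2 `C=CCNC(=O)/C(C)=C(\C)c1ccc(OC)cc1` gives 200 mg/kg in a toxicity assay on the whole organism (strain Icem-CET (SPF Caw)) for cytotoxicity, with Mus musculus as the target (a higher number here means that more compound is needed for the effect, a lower number that less compound is needed), a number that sits below that of compound 1 `C=CCNC(=O)/C(C)=C(/C)c1ccc(C)cc1`, which gives 280 mg/kg in this assay, by a gap within the usual scatter. Compound 3 `C=CCNC(=O)/C(C)=C(\C)c1ccc(C)cc1` has not yet been measured; it differs from compound 2 by methyl in place of methoxy on an aromatic carbon. Going by the values given here, no measured pair shows this same change, so the account expects no shift beyond the scatter in this assay, in either direction. Compound 3 is therefore estimated at 240 mg/kg, within a range of 130 mg/kg to 450 mg/kg, which means an expected step of a 1.2-fold higher number from compound 2 to compound 3 (0.08 log units; within the scatter).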

Compound 3, dose for half-maximal effect: 100 mg/kg
Estimate against measurement, compound 3: 2.4-fold (0.38 log units) above, outside the stated range (below it).
By their numbers in this assay, from the lowest: compounds 3, 2 and 1 (each within the scatter of the next, the first and the last beyond it).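

In this assay, methyl in place of methoxy on this aromatic carbon, para to a large group, gives a 2.0-fold lower number from compound 2 to compound 3 (0.30 log units; within the scatter), so this change at this position cannot be told apart from the usual scatter. Reversing the drawn double bond while keeping the methyl gives a 2.8-fold lower number from compound 1 to compound 3 (0.45 log units; beyond the scatter), a modest step beyond the scatter. That step can be traced to the double bond alone because of one fact: the fact that compounds 1 and 3 differ only in the configuration as drawn. Still open, as far as these compounds go, is whether the same step would appear with methoxy on the ring, and how an amine or a carboxylic acid on this aromatic carbon would read.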